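This account rests on a few compounds, and the source may have more. Where it says the series, first, only, none or still open, it means among the compounds named here.

In an ADME assay on MT4 cells (Homo sapiens) for cytotoxicity (on this read-out higher numbers stand for lower toxicity in this test and lower numbers for higher toxicity in this test), three compounds of one family have been measured. Compound 1 `COc1ccc(C(=O)CSc2nc(Cc3ccccc3Br)c(C)c(=O)[nH]2)cc1` gives only a limit, > 272000 nM. Compound 2 `COc1ccc(C(=O)CSc2nc(Cc3cccc(Br)c3)c(C)c(=O)[nH]2)cc1` likewise gives a limit, >= 196000 nM. Within the data shown here, compound 3 `CCc1c(Cc2ccccc2Br)nc(SCC(=O)c2ccc(OC)cc2)[nH]c1=O` is the one compound with a number, 187000 nM. Compound 2 differs from compound 1 by 3-bromophenyl in place of 2-bromophenyl on a saturated chain carbon bound to an aromatic carbon, and the reading is a step that the two limits leave unreadable from compound 1 to compound 2, as both the limit of > 272000 nM in this assay, at which 1 of the 3 values shown sits, and the limit of >= 196000 nM in this assay, at which 1 of the 3 values shown sits, show. Compound 3 differs from compound 1 by methyl in place of hydrogen on a saturated chain carbon bound to an aromatic carbon, giving an at least 1.4-fold lower number from compound 1 to compound 3 (0.16 log units; that floor lies within the scatter). Compound 4 `CCc1c(Cc2cccc(Br)c2)nc(SCC(=O)c2ccc(OC)cc2)[nH]c1=O` has not been measured; it differs from compound 3 by 3-bromophenyl in place of 2-bromophenyl on a saturated chain carbon bound to an aromatic carbon, the same change made from compound 1 to compound 2. That earlier step is unreadable, so the expectation rests on compound 3, whose value is 187000 nM, and the expected step is a 1.0-fold higher number from compound 3 to compound 4 (0.01 log units; within the scatter). Compound 4 is estimated at 190000 nM, between 100000 nM and 320000 nM.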

Compound 4, half-maximal cytotoxic concentration: 142000 nM
Beside the measured number, compound 4's estimate is 1.3-fold (0.13 log units) above it, within the range that was stated.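

In this assay, 3-bromophenyl in place of 2-bromophenyl gives a 1.3-fold lower number from compound 3 to compound 4 (0.12 log units; within the scatter), while the same change from compound 1 to compound 2 cannot be read, as both of those results are limits. Methyl in place of hydrogen on a saturated chain carbon bound to an aromatic carbon gives an at least 1.3-fold lower number from compound 2 to compound 4 (0.13 log units; that floor lies within the scatter). This shows no step beyond the scatter on either core and does not establish that the size of the change carries from one core to another: the same change on two cores in this assay, an at least 1.4-fold lower number (0.16 log units; that floor lies within the scatter) from compound 1 to compound 3 and an at least 1.3-fold lower number (0.13 log units; that floor lies within the scatter) from compound 2 to compound 4; the limit leaves it open whether they differ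

The compounds shown leave open how the cytotoxicity read-out responds to a longer chain in place of that methyl. They also leave open the effect of an amine or a carboxylic acid in place of the bromine.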